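Adding a second methoxy to compound 2

A few compounds are considered here, and "the series" means these few. Any claim that something is new, unique, unknown or untested is made for them only; others in the source may bear on it.

compound 1, `CCSC(=S)SCC(=O)c1ccc(NS(C)(=O)=O)cc1`: 39800 nM
compound 2, `CCSC(=S)SCC(=O)c1ccc(OC)cc1`: 2510 nM
compound 3, `CCSC(=S)SCC(=O)c1ccc(OC(F)F)cc1`: 3980 nM

In a functional assay on HeLa cells (Homo sapiens) for antiproliferative activity, read by resazurin assay (on this read-out higher numbers stand for weaker inhibition and lower numbers for stronger inhibition), compound 2 sits at the low end of the three numbers, level with compound 3 within the scatter: a 1.6-fold higher number from compound 2 to compound 3 (0.20 log units; within the scatter). Compound 1 lies far off: a 16-fold lower number from compound 1 to compound 2 (1.20 log units; beyond the scatter), a large step, and a 10-fold lower number from compound 1 to compound 3 (1.00 log units; beyond the scatter), a modest one. Both of these remove methanesulfonamido, which compound 4, `CCSC(=S)SCC(=O)c1ccc(OC)c(OC)c1`, does not do. Compound 4 carries methoxy in place of hydrogen on an aromatic carbon, ortho to a methoxy group. Within the data shown here, no measured step adds a group in place of hydrogen, so the nearest guide is the small 1.6-fold higher number from compound 2 to compound 3 (0.20 log units; within the scatter). The expected step is a 1.1-fold higher number from compound 2 to compound 4 (0.05 log units; within the scatter), none beyond the scatter. For compound 4 the estimated value is 2800 nM, with an expected range of 1000 nM to 8000 nM.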

Compound 4, half-maximal inhibitory concentration: 5010 nM
Beside the measured number, compound 4's estimate is 1.8-fold (0.25 log units) below it, and the stated range covers the measured number.
By their numbers in this assay, from the lowest: compounds 2, 3 and 4 (each within the scatter of the next); then compound 1.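

In this assay, methoxy in place of hydrogen on an aromatic carbon, ortho to a methoxy group, gives a 2.0-fold higher number from compound 2 to compound 4 (0.30 log units; within the scatter), a step within the scatter. Among these compounds, this is the first change at a ring position that carries hydrogen in compounds 1 to 3, and the earlier steps only exchanged the group that is methoxy in compound 2, so this position accepts methoxy with no step beyond the scatter. No supporting measurement bears on this result.

Still open, going by these compounds, is how a hydroxyl, an amine or a longer ethoxy chain at this position would read. Also open, on these data alone, is whether methoxy here would read the same without the neighbouring methoxy group.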